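Swapping Methoxyphenyl for Thiophene in a Thiosemicarbazone

The source may report more compounds than this note shows. Statements on the series, on what has been measured and on what is new or still open speak of the compounds shown alone.

Measured compounds:
compound 1, `COc1ccc(/C=N/NC(=S)NC(C)(C)[C@H]2CC=C(C)CC2)cc1`, 21200 nM
compound 2, `CC1=CC[C@H](C(C)(C)NC(=S)N/N=C/c2cccc([N+](=O)[O-])c2)CC1`, > 100000 nM

For the measured compounds named here, in a functional assay on OVCAR-3 cells (Homo sapiens) for inhibition, read by sulforhodamine B assay, with a stated time of 48 h (a higher number here means a weaker inhibitor of growth, a lower number a stronger inhibitor of growth), compound 1 gives 21200 nM, the only actual number among the two measured compounds. Compound 2 gives > 100000 nM, which is a limit of the assay and not a number. Compound 2 therefore sits at the limit of > 100000 nM in this assay, at which 1 of the 2 values shown sits.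

Compound 3, `CC1=CC[C@H](C(C)(C)NC(=S)N/N=C/c2cccs2)CC1`, has not yet been measured. It differs from compound 1 in a single place: thiophen-2-yl in place of 4-methoxyphenyl on a carbon with a double bond to nitrogen. Going by the values given here, no two measured compounds differ in only one place, so there is no measured step to calibrate this change against. The step from compound 1 to compound 3, a 1.5-fold higher number from compound 1 to compound 3 (0.18 log units; within the scatter), is expected to be a modest weakening, one that may not clearly exceed the usual scatter. For compound 3 the estimate in this assay is 32000 nM, with a likely range from 10000 nM to 100000 nM.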

Compound 3, concentration for total growth inhibition: 35100 nM
Estimate against measurement, compound 3: 1.1-fold (0.04 log units) below, and the stated range covers the measured number.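

In this assay, for the compounds shown here, thiophen-2-yl in place of 4-methoxyphenyl gives a 1.7-fold higher number from compound 1 to compound 3 (0.22 log units; within the scatter), the only step so far between two measured compounds that differ in one place. At this position, on a carbon with a double bond to nitrogen, a five-membered aromatic ring with 1 hetero atom can therefore replace a six-membered aromatic ring of carbon only without a change beyond the scatter. Nothing shown here accounts for the size of this step.

As far as these compounds go, whether a group of another kind at this position, such as an amine or a carboxylic acid, would move the number beyond the scatter remains open. A single step in one cell line also leaves open whether the same swap would behave alike on a different core.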